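The compounds below may be only part of what the source reports. "The series", "measured", "known", "first", "only" and "open" are said of these compounds alone.

Measured compounds:
- compound 1, `C#CCN(CCC)Cc1cn(-c2cc(NC(=S)NCC)ncn2)cn1`: 1.76%
- compound 2, `C#CCN(CC#C)Cc1cn(-c2cc(NC(=S)NCC)ncn2)cn1`: 15.5%

In an assay on isolated protein for inhibition of Amine oxidase [flavin-containing] A (Homo sapiens), read by fluorescence and Amplex Red, with a stated time of 15 min, tested at 50 uM (a lower number here means less inhibition, a higher number more inhibition at the concentration tested (going by the name of the read-out)), compound 2 stands highest of the two numbers shown. Within the data shown here, the only measured step, a number 13.7 percentage points higher from compound 1 to compound 2 (beyond the scatter), shows that a second propargyl group on the amine nitrogen raised the read-out by a modest but real amount. Compound 3, `C#CCN1CCN(Cc2cn(-c3cc(NC(=S)NCC)ncn3)cn2)CC1`, has not yet been measured in this assay. It differs from compound 2 by 4-propargylpiperazin-1-yl in place of dipropargylamino on a saturated chain carbon bound to an aromatic carbon. The change removes one of the two propargyl groups that distinguished compound 2 from compound 1, and the remaining propargyl now sits on the ring nitrogen of the piperazine rather than directly on the nitrogen bound to the benzylic carbon. Among the measured compounds shown here, the one step that bears on this, a number 13.7 percentage points higher from compound 1 to compound 2 (beyond the scatter), suggests that losing a propargyl at that position costs a modest amount of inhibition, so a downward step of about that size is expected, with a number 11.5 percentage points lower from compound 2 to compound 3 (beyond the scatter) as the estimated change. Compound 3 is therefore expected to give 4% in this assay, within a range from -6% to 16%.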

Compound 3, a percentage reported as inhibition, at one concentration (the size of the read-out at that concentration, not a potency): 9.22%
Beside the measured number, compound 3's estimate is 5.2 percentage points below it; the measured number falls inside the stated range.
By their numbers in this assay, from the lowest: compounds 1, 3 and 2 (each within the scatter of the next, the first and the last beyond it).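

In this assay, placing 4-propargylpiperazin-1-yl on a saturated chain carbon bound to an aromatic carbon gives a number 6.3 percentage points lower from compound 2 to compound 3 (within the scatter) and also a number 7.5 percentage points higher from compound 1 to compound 3 (within the scatter) so compound 3 cannot be separated from either neighbour, even though compound 1 and compound 2 are separated from each other. The number of triple bonds outside aromatic rings therefore does not sort these three compounds, and the earlier step alone could not show this: compound 3 carries one such bond and a six-membered non-aromatic ring with 2 hetero atoms, yet its result is compatible with both the one-propargyl and the two-propargyl amine. No measured evidence accounts for these numbers.

A 4-methylpiperazin-1-yl group at this place would test whether the propargyl on the piperazine contributes anything beyond the ring itself, and a morpholin-4-yl group would test whether the second ring nitrogen matters. All three results are readings at a single concentration, so they leave open how the compounds compare in potency.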